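Ester in place of diol on the chain of compound 2

The compounds below may be only part of what the source reports. "The series", "measured", "known", "first", "only" and "open" are said of these compounds alone.

Compound 2 `CCCc1nc(C)c2cnn(CC(O)CO)c(=O)n12` carries a 2,3-dihydroxypropyl chain on the shared core. In a functional assay for inhibition, with Homo sapiens as the target (a higher number here means a weaker inhibitor, a lower number a stronger inhibitor), compound 2 gives > 48000 nM, which is a limit of the assay and not a number. Compound 1 `CCCc1nc(C)c2cnn(CC3CC3)c(=O)n12` in this assay gives > 48000 nM, again a limit. Compound 3 `CCCc1nc(C)c2c(C)nn(CC(O)CO)c(=O)n12` in this assay gives > 48000 nM, also a limit. Both measured steps, a step that the two limits leave unreadable from compound 1 to compound 2 and a step that the two limits leave unreadable from compound 2 to compound 3, are thus unreadable, and the limit of > 48000 nM in this assay, at which 3 of the 3 values shown sit, is all that the measured steps show. Compound 4 `CCCc1nc(C)c2cnn(CC(=O)OCC)c(=O)n12` differs from compound 2 by ethoxycarbonyl in place of 1,2-dihydroxyethyl on a saturated chain carbon bound to an aromatic nitrogen. Neither measured step bears on this change in a readable way, so no step beyond the scatter is expected in this assay, and a further limit is the likeliest outcome. Compound 4 is expected to give 60000 nM (range 20000 nM to 200000 nM). The step this estimate implies is a step that the limit leaves unreadable from compound 2 to compound 4, expected to sit within the scatter.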

Compound 4, half-maximal inhibitory concentration: > 48000 nM
Compound 4 was reported as a limit; the forecaster's own chance of this, stated with the estimate: 85%; the middle value lies beyond the limit too.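

Compound 4, like compound 1 and compound 2, stands only as a limit, so neither new step can be read: the limit of > 48000 nM in this assay, at which 4 of the 4 values shown sit.

As far as these compounds go, whether the chain on the shared core changes anything in this assay stays open.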